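The source may hold more compounds than are shown below. What is called first, only, known or untested is meant among the compounds shown, and "the series" means these compounds.

Measured compounds in an assay on cells for displacement of a labelled ligand from Glucagon receptor (Homo sapiens), in the presence of a further agent that is not named here; on this read-out lower numbers stand for stronger inhibition and higher numbers for weaker inhibition:
compound 1 `CCCC(Oc1ccc(-n2cc(OC)cn2)cc1)c1ccc(C(=O)NCCC(=O)O)cc1` gives 4400 nM.
compound 2 `CCCC(Oc1ccc(-n2cc(C(=O)N(C)C)cn2)cc1)c1ccc(C(=O)NCCC(=O)O)cc1` gives 6500 nM.

Compound 2 stands highest of the two numbers in this assay, and its nearest neighbour is compound 1, from which it is separated by a 1.5-fold higher number from compound 1 to compound 2 (0.17 log units; within the scatter); the two values therefore cannot be ordered. Compound 3 `CCCC(Oc1ccc(-n2cc(C(F)(F)F)c(C)n2)cc1)c1ccc(C(=O)NCCC(=O)O)cc1` differs from compound 2 by 3-methyl-4-(trifluoromethyl)-1H-pyrazol-1-yl in place of 4-(dimethylcarbamoyl)-1H-pyrazol-1-yl on an aromatic carbon. Within the data shown here, no measured step touches a 3-methyl-4-(trifluoromethyl)-1H-pyrazol-1-yl group, so nothing recorded bears directly on this exchange. Among the measured compounds shown here, the only recorded step, a 1.5-fold higher number from compound 1 to compound 2 (0.17 log units; within the scatter), replaced one substituent on the same five-membered ring with another and stayed within the scatter. On that basis compound 3 is expected to show a step of a 1.4-fold lower number from compound 2 to compound 3 (0.16 log units; within the scatter) in this assay, with no clear direction beyond the scatter. Compound 3 is accordingly estimated at 4500 nM, within a range from 1200 nM to 18000 nM.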

Compound 3, inhibition constant: 1100 nM
For compound 3 the middle estimate is 4.1-fold (0.61 log units) above the measured one; measured number outside the range, below it.
By their numbers in this assay, from the lowest: compound 3; then compounds 1 and 2 (each within the scatter of the next).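

In this assay this position turns out to be able to move the number beyond the scatter, which the exchange between methoxy and dimethylcarbamoyl had not shown: 3-methyl-4-(trifluoromethyl)-1H-pyrazol-1-yl brings a 5.9-fold lower number from compound 2 to compound 3 (0.77 log units; beyond the scatter) and a 4.0-fold lower number from compound 1 to compound 3 (0.60 log units; beyond the scatter). Both steps are modest, yet compound 3 stands apart from compound 1 and compound 2, whose own values cannot be ordered. Nothing measured alongside these values offers an explanation for the step.

As far as these compounds go, it remains open whether the trifluoromethyl group, the methyl group or the two together carry the step, as both enter in a single change. Also open, from the compounds shown here alone, is how a nitrile or an amine on the same pyrazole would read in this assay.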